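The compounds below may be only part of what the source reports. "The series", "measured", "known", "first", "only" and "open" are said of these compounds alone.

Measured so far:
compound 1 `O=C1c2ccc(OCc3cccc(-c4ccccc4)c3)cc2CN1C1CCCC1` — > 5000 nM
compound 2 `CC(C)CCn1sc2cc(OCc3cccc(-c4ccc(Cl)c(C(=O)O)c4)c3)ccc2c1=O` — 650 nM

In an assay on HEK293 cells for positive allosteric modulation of metabotropic glutamate receptor 2 (Rattus norvegicus), read by thallium flux (a lower number here means that less compound is needed, a higher number that more compound is needed for the effect), compound 1 gives > 5000 nM, which is a limit of the assay and not a number. Compound 1 therefore stands at the limit of > 5000 nM in this assay, at which 1 of the 2 values shown sits, and no precise value exists for it. Among the measured compounds shown here, compound 2, built on a different core and also bearing a carboxylic acid, gives 650 nM in this assay; no step between compound 1 and compound 2 is measured, so the two values are only set side by side.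

Compound 3 `O=C(O)c1cc(F)cc(-c2cccc(COc3ccc4c(c3)CN(C3CCCC3)C4=O)c2)c1` differs from compound 1 by 3-carboxy-5-fluorophenyl in place of phenyl on an aromatic carbon. For the measured compounds named here, no measured step covers this change. Going by the values given here, compound 2, the only compound with a number, carries a carboxylic acid and gives 650 nM. From the limit of > 5000 nM in this assay, at which 1 of the 2 values shown sits, at which compound 1 sits, a downward step beyond the scatter is expected for compound 3, its size left open by that limit. Compound 3 is estimated at 1500 nM, range 400 nM to 6000 nM. The expected step of an at least 3.3-fold lower number from compound 1 to compound 3 (0.52 log units; beyond the scatter) points downward, with a real chance that only a limit is returned again.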

Compound 3, half-maximal effective concentration: 130 nM
Compound 3: middle estimate off by 12-fold (1.06 log units), on the high side; measured number outside the range, below it.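

Among the compounds shown here, on the shared core, 3-carboxy-5-fluorophenyl in place of phenyl on an aromatic carbon gives in this assay an at least 38-fold lower number from compound 1 to compound 3 (1.58 log units; beyond the scatter), the only step that can be read so far. As far as these compounds go, its full size stays unknown, since compound 1 stands at a limit of the assay and not at a number: the limit of > 5000 nM in this assay, at which 1 of the 3 values shown sits. Compound 3 shows that, on this core, a substituted ring at this aromatic carbon, meta to a large group, gives a measured value, which the plain phenyl of compound 1 did not.

How much of the step belongs to the carboxylic acid and how much to the fluorine stays open, as no compound shown on this core carries one without the other. From the compounds shown here alone, whether a tetrazole or a primary amide could stand in place of the carboxylic acid also stays open.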